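A few compounds are considered here, and "the series" means these few. Any claim that something is new, unique, unknown or untested is made for them only; others in the source may bear on it.

In an assay on CHO cells with Alpha-2B adrenergic receptor (Homo sapiens) as the target (on this read-out higher numbers stand for larger maximal responses and lower numbers for smaller maximal responses), the measured compounds and their values are:

compound 1 `CC(C)Oc1ccccc1OC(C)C1=NCCN1`: 0.5
compound 2 `COc1ccccc1OC(C)C1=NCCN1`: 0.5

Compound 1 stands level with compound 2 at the digits shown. Within the data shown here, the only measured step, no change at the digits printed from compound 1 to compound 2 (within the scatter), lies within the scatter, so exchanging one group for another on the oxygen on the aromatic ring left the maximal response where it was. Compound 3 `C=COc1ccccc1OC(C)C1=NCCN1` has not yet been measured. It differs from compound 1 in one place: vinyl in place of isopropyl on an oxygen on an aromatic ring. The step from compound 1 to compound 2 is the one that bears on this change, since it alters the same oxygen on the aromatic ring, and it showed no change beyond the scatter. The same outcome is expected here. Compound 3 is therefore estimated to give 0.5, within the range 0.35 to 0.65. The step this estimate means, no change at the digits printed from compound 1 to compound 3 (within the scatter), is expected to be none beyond the scatter.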

Compound 3, intrinsic activity: the largest response reached, as a fraction of the reference agonist's: 0.45
Beside the measured number, compound 3's estimate is 0.050 above it; the measured number falls inside the stated range.
By their numbers in this assay, from the lowest: compounds 3, 1 and 2 (each within the scatter of the next).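

In this assay, vinyl on the oxygen on the aromatic ring can now be compared with both earlier groups: isopropyl (a number 0.050 lower from compound 1 to compound 3 (within the scatter)) and methyl (a number 0.050 lower from compound 2 to compound 3 (within the scatter)). A third group, and the first here with a double bond outside aromatic rings, therefore leaves the maximal response within the scatter, so this read-out does not separate the three groups at this oxygen. No measurement is available that could explain this result. The compounds shown leave open whether the response would hold with a longer chain such as butyl, with a benzyl group, or with a chain ending in an amine on the same oxygen. They also speak only to the largest response reached, not to how much compound is needed to reach it.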